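This account rests on a few compounds, and the source may have more. Where it says the series, first, only, none or still open, it means among the compounds named here.

Working notes on the series: three analogues of the shared core, differing only in the halogen on the aromatic ring, have been measured in a functional assay on K562 cells (Homo sapiens) for cytotoxicity, read by MTT assay, with a stated time of 72 h; on this read-out higher numbers stand for weaker inhibition and lower numbers for stronger inhibition. In that read-out, compound 1 `Cc1ccc(S(=O)(=O)n2cc(COC3=C/C(=N\c4ccc(I)cc4)c4ccccc4C3=O)nn2)cc1` gives 10800 nM, and compound 2 `Cc1ccc(S(=O)(=O)n2cc(COC3=C/C(=N\c4ccc(Br)cc4)c4ccccc4C3=O)nn2)cc1` gives 5400 nM. Compound 3 `Cc1ccc(S(=O)(=O)n2cc(COC3=C/C(=N\c4ccc(F)cc4)c4ccccc4C3=O)nn2)cc1` gives 7700 nM, which lies within the scatter of both other values.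

The next step leads from compound 3 to compound 4 `Cc1ccc(S(=O)(=O)n2cc(COC3=C/C(=N\c4ccc(Cl)cc4)c4ccccc4C3=O)nn2)cc1`. It places chloro in place of fluoro on an aromatic carbon, para to a large group, turning 4-fluorophenyl into 4-chlorophenyl: chloro in place of fluoro on an aromatic carbon.

Going by the values given here, three measured steps bear on this change, all of them exchanges of one halogen for another at the same place. They are a 1.4-fold higher number from compound 2 to compound 3 (0.15 log units; within the scatter), a 1.4-fold lower number from compound 1 to compound 3 (0.15 log units; within the scatter) and a 2.0-fold lower number from compound 1 to compound 2 (0.30 log units; within the scatter). Each stays within the scatter, so the fluoro, bromo and iodo compounds cannot be told apart in this assay. No step beyond the scatter is therefore expected for the chloro analogue. The estimated step is a 1.1-fold lower number from compound 3 to compound 4 (0.04 log units; within the scatter), and it is not expected to be distinguishable from the scatter. Compound 4 is estimated at 7000 nM, with an expected range from 3800 nM to 13000 nM.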

Compound 4, half-maximal inhibitory concentration: 9800 nM
Beside the measured number, compound 4's estimate is 1.4-fold (0.15 log units) below it, and the stated range covers the measured number.
By their numbers in this assay, from the lowest: compounds 2, 3, 4 and 1 (each within the scatter of the next).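

In this assay, chloro in place of fluoro gives a 1.3-fold higher number from compound 3 to compound 4 (0.10 log units; within the scatter), chloro in place of bromo gives a 1.8-fold higher number from compound 2 to compound 4 (0.26 log units; within the scatter), and chloro in place of iodo gives a 1.1-fold lower number from compound 1 to compound 4 (0.04 log units; within the scatter). With 4-chlorophenyl added, every exchange among fluoro, chloro, bromo and iodo at this place, on an aromatic carbon para to a large group, stays within the scatter, so the four compounds cannot be ranked and the choice among these four halogens does not separate them in this read-out. Nothing available bears on why these halogen exchanges leave the compounds indistinguishable.

The compounds shown leave open whether a group other than a halogen at this place, such as an amine, a methoxy group or a carboxylic acid, would give a step beyond the scatter. Also open, as far as these compounds go, is whether the four halogens stay this close once another part of the shared core is changed.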